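The source may report more compounds than this note shows. Statements on the series, on what has been measured and on what is new or still open speak of the compounds shown alone.

Measured compounds:
Compound 1, `COc1cc2ncnc(Nc3ccc(Cl)cc3)c2cc1OCCCCC(=O)Nc1ccc(S(N)(=O)=O)cc1`, 31800 nM.
Compound 2, `COc1cc2ncnc(Nc3cccc(Cl)c3F)c2cc1OCCCCC(=O)Nc1ccc(S(N)(=O)=O)cc1`, 6930 nM.

Both were tested in a functional assay on NCI-H1975 cells (Homo sapiens) for antiproliferative activity, read by MTT assay, with a stated time of 72 h; a lower number here means a stronger inhibitor, a higher number a weaker inhibitor. Compound 2 stands lowest of the two numbers; its nearest neighbour is compound 1, which gives the higher number of the pair. Compound 3, `COc1cc2ncnc(Nc3ccc(OC(F)(F)F)cc3)c2cc1OCCCCC(=O)Nc1ccc(S(N)(=O)=O)cc1`, has not yet been measured in this assay. It differs from compound 2 in one place: 4-(trifluoromethoxy)phenyl in place of 3-chloro-2-fluorophenyl on a nitrogen on an aromatic ring. Among the compounds with values here, one measured step bears on this change, as it too replaces the group on the same nitrogen: a 4.6-fold lower number from compound 1 to compound 2 (0.66 log units; beyond the scatter). That step was modest in size and ran downward. The entering 4-(trifluoromethoxy)phenyl resembles the 4-chlorophenyl of compound 1 more closely than it resembles the 3-chloro-2-fluorophenyl of compound 2, so the expected step for compound 3 runs in the opposite direction, back toward the number of compound 1, and is estimated at roughly similar size, a 2.9-fold higher number from compound 2 to compound 3 (0.46 log units; beyond the scatter). The estimate for compound 3 in this assay is 20000 nM, with an expected range from 6000 nM to 60000 nM.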

Compound 3, half-maximal inhibitory concentration: 8770 nM
Compound 3: the middle estimate sits 2.3-fold (0.36 log units) above what was measured; measured number inside the range.
By their numbers in this assay, from the lowest: compounds 2 and 3 (each within the scatter of the next); then compound 1.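

In this assay, swapping one aryl group on this nitrogen for another with a different substitution pattern and different atoms made no difference that could be read, a 1.3-fold higher number from compound 2 to compound 3 (0.10 log units; within the scatter), so the lower number of compound 2 does not depend on keeping the 3-chloro-2-fluorophenyl group. The other new step, trifluoromethoxy in place of chloro on an aromatic carbon, gives a 3.6-fold lower number from compound 1 to compound 3 (0.56 log units; beyond the scatter), which shows that a single group on the ring, as in 4-(trifluoromethoxy)phenyl, can give a number level with that of compound 2, and that among these three compounds it is the 4-chlorophenyl of compound 1 that stands apart with the highest number. Nothing among the data shown accounts for why these changes have the sizes they do.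

The compounds shown leave open how an unsubstituted phenyl, a 4-bromophenyl or a 4-methoxyphenyl on the same nitrogen would compare with these three. They also say nothing about whether a longer chain in the linker, or a carboxylic acid in place of the sulfonamide, would shift the numbers of compound 2 and compound 3 alike.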